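Phenylethynyl bicyclic nucleosides: enol side chain in place of methyl

The compounds below may be only part of what the source reports. "The series", "measured", "known", "first", "only" and "open" are said of these compounds alone.

Measured compounds:
compound 1 `CNC(=O)[C@@]12C[C@@H]1[C@@H](n1cnc3cnc(C#Cc4ccc(Cl)s4)nc31)[C@H](O)[C@@H]2O`, 396 nM
compound 2 `CNC(=O)[C@@]12C[C@@H]1[C@@H](n1cnc3c(C)nc(C#Cc4ccccc4)nc31)[C@H](O)[C@@H]2O`, 158 nM

In an assay on HEK293 cells for displacement of a labelled ligand from adenosine receptor A3 (Mus musculus), read by scintillation counting, with a stated time of 60 min (a lower number here means a stronger inhibitor, a higher number a weaker inhibitor), compound 2 gives 158 nM, the lowest of the two numbers; compound 1 gives 396 nM, a gap beyond the scatter. Compound 3 `CNC(=O)[C@@]12C[C@@H]1[C@@H](n1cnc3c(/C=C(\O)c4ccccc4)nc(C#Cc4ccccc4)nc31)[C@H](O)[C@@H]2O` is not yet measured. It differs from compound 2 in one place: 2-hydroxy-2-phenylethenyl in place of methyl on an aromatic carbon. Nothing between measured compounds shows what such a replacement does on this core, so the expectation rests on compound 2 alone. Entering a group with one six-membered aromatic ring and a hydrogen-bond donor where a methyl stood is a large change at a crowded part of the fused system, and a weakening of moderate size is expected, though a result within the scatter would not surprise. The expected step of a 2.0-fold higher number from compound 2 to compound 3 (0.31 log units; beyond the scatter) is estimated to lie roughly at the edge of the scatter. Compound 3 is expected near 320 nM, in a range of 80 nM to 1300 nM.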

Compound 3, inhibition constant: 136 nM
Estimate against measurement, compound 3: 2.4-fold (0.37 log units) above; low and high end bracket the measured number.
By their numbers in this assay, from the lowest: compounds 3 and 2 (each within the scatter of the next); then compound 1.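

In this assay, 2-hydroxy-2-phenylethenyl in place of methyl on an aromatic carbon gives a 1.2-fold lower number from compound 2 to compound 3 (0.07 log units; within the scatter), so this position, next to the ring nitrogen and ortho to a fused ring, accepts a far larger group with no change beyond the scatter. On this pair, going from one heavy atom to nine, with a six-membered aromatic ring and a hydrogen-bond donor added, leaves the inhibition constant where it was. No measurement at hand explains this result.

From the compounds shown here alone, whether the hydroxyl or the phenyl ring matters here remains open, and a plain 2-phenylethenyl group, an amine or a longer alkyl chain on this carbon would help separate them. Compound 1 differs from compound 2 in more than one place, so the contribution of the methyl itself cannot be read.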